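The source may report more compounds than this note shows. Statements on the series, on what has been measured and on what is new or still open speak of the compounds shown alone.

Compound 1 `CCC(=O)Nc1c(C)c(C(OC(C)(C)C)C(=O)O)c(-c2ccc(C)c(C)c2)c(C)c1-c1ccc(C)c(C)c1` gives 15000 nM in an ADME assay on MT4 cells (Homo sapiens) for cytotoxicity, read by MTT assay, with a stated time of 4 days; on this read-out higher numbers stand for lower toxicity in this test and lower numbers for higher toxicity in this test.
Compound 2 `Cc1ccc(-c2c(C)c(-c3ccc(Cl)cc3)c(C(OC(C)(C)C)C(=O)O)c(C)c2NS(C)(=O)=O)cc1C` gives 26000 nM in this assay.

Going by the values given here, of the two numbers measured so far, compound 1 gives the lowest one. Compound 2 lies within the usual scatter of compound 1, so the two values cannot be told apart; they only show that both compounds sit in a similar region of this assay.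

Compound 3 `Cc1ccc(-c2c(C)c(-c3ccc(C)c(C)c3)c(C(OC(C)(C)C)C(=O)O)c(C)c2NC(=O)Nc2ccccc2)cc1C` shares the core of compound 1 and differs from it in a single spot: anilino in place of ethyl on a carbonyl carbon. Among the compounds with values here, no pair among the measured compounds shows this particular change, so there is no measured step to lean on. Within the data shown here, compound 1 and compound 2 together suggest that substituents at this amide-type nitrogen leave the read-out in roughly the same range, and that is the only guide available.

On that basis compound 3 is expected to stay close to compound 1, with a step of a 1.3-fold lower number from compound 1 to compound 3 (0.10 log units; within the scatter) that lies within the scatter. The estimate for compound 3 is 12000 nM, with a range from 4000 nM to 40000 nM.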

Compound 3, half-maximal cytotoxic concentration: 8000 nM
Beside the measured number, compound 3's estimate is 1.5-fold (0.18 log units) above it, within the range that was stated.
By their numbers in this assay, from the lowest: compounds 3, 1 and 2 (each within the scatter of the next, the first and the last beyond it).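

Going by these compounds alone, the step from ethyl to anilino on a carbonyl carbon is the first measured change at this position, and in this assay it amounts to a 1.9-fold lower number from compound 1 to compound 3 (0.27 log units; within the scatter), which lies within the scatter. Compound 1 and compound 3 therefore cannot be told apart in this test, even though the change from propanoylamino to (phenylcarbamoyl)amino brings in a six-membered aromatic ring and a hydrogen-bond donor. For this one pair, then, a clearly larger group on the carbonyl carbon gives no measurable difference in the read-out, and nothing at hand gives a reason for this result.

As far as these compounds go, one matched pair cannot show how far this holds, so it remains open whether a carboxylic acid or a primary amine on the ring of the anilino group, or a longer alkyl chain such as hexyl in place of ethyl, would also leave the number in this range. From the compounds shown here alone, it also remains open which kind of group on the carbonyl carbon, if any, would produce a step that rises clearly beyond the scatter.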